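The compounds below may be only part of what the source reports. "The series", "measured", "known", "first", "only" and "open" are said of these compounds alone.

Compound 1, `COc1cc(N)c(Cl)cc1C(=O)CCC1CCN(CCNS(=O)(=O)c2ccc(NC(C)=O)cc2)CC1`: 7%
Compound 2, `COc1ccc(S(=O)(=O)NCCN2CCC(CCC(=O)c3cc(Cl)c(N)cc3OC)CC2)cc1`: 36%

Of the compounds shown here, two have been measured in an assay on HEK293 cells for displacement of a labelled ligand from 5-hydroxytryptamine receptor 6 (Homo sapiens), with a stated time of 60 min, tested at 0.01 uM, in the presence of a further agent that is not named here; a higher number here means a stronger effect of the compound at the concentration tested, a lower number a weaker effect. Among the compounds with values here, compound 2 stands highest of the two numbers, and the only measured step, a number 29 percentage points higher from compound 1 to compound 2 (beyond the scatter), comes from a methoxy in place of acetamido on an aromatic carbon.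

Compound 3, `COc1ccc(S(=O)(=O)NCCN2CCC(CCC(=O)c3cc(Cl)c(N)cc3OC)CC2)c(OC)c1`, has not yet been measured. Relative to compound 2 the change is methoxy in place of hydrogen on an aromatic carbon, so the 4-methoxyphenyl becomes a 2,4-dimethoxyphenyl, the new group sitting ortho to a large group and meta to a methoxy group. Within the data shown here, no measured step speaks to this change: the one known step swapped acetamido for methoxy rather than adding a methoxy to a ring that already carries one. Without a precedent, the step of a number 2 percentage points higher from compound 2 to compound 3 (within the scatter) is expected to stay within the scatter. Compound 3 is therefore estimated at 38%, in a range from 15% to 60%.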

Compound 3, a percentage reported as inhibition, at one concentration (the size of the read-out at that concentration, not a potency): "not active" (no number reported)
Compound 3 has no reported number here; no gap can be computed for the estimate.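

Within the data shown here, compound 3 is reported as "not active", with no number, in this assay, so no step from compound 2 to compound 3 can be read. Nothing shown here bears on this result. As far as these compounds go, how far adding the methoxy changes the read-out remains open.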